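Removing the Nitro Group from a Diaryl Hydrazone

The source may hold more compounds than are shown below. What is called first, only, known or untested is meant among the compounds shown, and "the series" means these compounds.

Measured compounds:
compound 1, `O=[N+]([O-])c1ccccc1NN=C(c1ccc(O)cc1)c1ccc(O)cc1`, 4.7 ug/mL
compound 2, `O=[N+]([O-])c1ccc(N/N=C(\c2ccc(O)cc2)c2ccc(Cl)cc2)c([N+](=O)[O-])c1`, > 10 ug/mL

In a functional assay on cells (Colon carcinoma cell, Homo sapiens) for cytotoxicity (a higher number here means a weaker inhibitor, a lower number a stronger inhibitor), compound 1 gives 4.7 ug/mL, the only actual number among the two results shown. For compound 2 the result of > 10 ug/mL is a limit of this assay rather than a number, and it sits at the limit of > 10 ug/mL in this assay, at which 1 of the 2 values shown sits.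

Compound 3, `Oc1ccc(C(=NNc2ccccc2)c2ccc(O)cc2)cc1`, differs from compound 1 by hydrogen in place of nitro on an aromatic carbon. Among the compounds with values here, no step between two measured compounds is available to gauge such a change, so the expectation rests on the single number of compound 1 alone. The step from compound 1 to compound 3 is expected to be a 1.7-fold higher number from compound 1 to compound 3 (0.23 log units; within the scatter), a modest weakening that barely exceeds the scatter. Compound 3 is therefore estimated at 8 ug/mL in this assay, within a range of 2.5 ug/mL to 25 ug/mL.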

Compound 3, half-maximal inhibitory concentration: > 5 ug/mL
Compound 3: no number, only a limit; the forecaster's own chance of this, stated with the estimate: 35%; the middle value is on the limit's open side.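

Compound 3 reaches only a limit and not a number in this assay: the limit of > 5 ug/mL in this assay, at which 1 of the 3 values shown sits.

Hydrogen in place of nitro, on an aromatic carbon ortho to a large group, gives an at least 1.0-fold higher number from compound 1 to compound 3 (0.02 log units; that floor lies within the scatter), the only step at this position among the compounds shown. This is a floor and not a measured size, so the result fits a change within the scatter as well as a much larger weakening, and it neither shows that the nitro group is needed nor that it can be lost without cost.

On these data alone, the true size of this step stays open, as it would need a number for compound 3 rather than a limit. Also open, as far as these compounds go, is how an amine or a methoxy group on the same aromatic carbon would compare with the nitro group of compound 1.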